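The compounds below may be only part of what the source reports. "The series", "measured", "known", "first", "only" and "open" are said of these compounds alone.

Working notes on the series in a functional assay on HT-29 cells (Homo sapiens) for cytotoxicity, read by MTT assay; on this read-out higher numbers stand for weaker inhibition and lower numbers for stronger inhibition.

Of the compounds shown here, three have been measured. Compound 2 `CC(=O)O[C@@H]1OC(=O)[C@@](C)(C(C)=O)[C@@H]1C` gives 12000 nM. Compound 3 `CC(=O)[C@]1(C)C(=O)O[C@@H](OC(=O)C(C)(C)C)[C@H]1C` gives 9000 nM, the second highest of the three numbers; the step of a 1.3-fold lower number from compound 2 to compound 3 (0.12 log units; within the scatter) shows that the change from methyl to tert-butyl on the carbonyl carbon left the number where it was. Compound 1 `CC(=O)[C@@]1(C)C(=O)O[C@@H](OC(=O)c2ccccc2)[C@H]1C` gives 1000 nM, a lower number than compound 3 by an amount that lies beyond the scatter, but compound 1 differs from compound 3 in more than one place, so its value can only be read as it stands.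

The next compound, compound 4 `CC(=O)[C@]1(C)C(=O)O[C@@H](OC(=O)c2ccccc2)[C@H]1C`, carries phenyl in place of tert-butyl on a carbonyl carbon. Among the measured compounds shown here, no measured step covers this change on its own. For the measured compounds named here, the only step on the same carbonyl carbon, from compound 2 to compound 3, was within the scatter, while the benzoyl-bearing compound 1 sits at the low end of the measured numbers. The expectation is therefore a modest move to a lower number, a 3.0-fold lower number from compound 3 to compound 4 (0.48 log units; beyond the scatter), with wide uncertainty. Compound 4 is estimated at 3000 nM, with a range from 800 nM to 12000 nM.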

Compound 4, half-maximal inhibitory concentration: 6000 nM
Estimate against measurement, compound 4: 2.0-fold (0.30 log units) below; measured number inside the range.
By their numbers in this assay, from the lowest: compound 1; then compounds 4, 3 and 2 (each within the scatter of the next).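

In this assay the group on this carbonyl carbon has so far made no readable difference: a 1.5-fold lower number from compound 3 to compound 4 (0.18 log units; within the scatter) and a 2.0-fold lower number from compound 2 to compound 4 (0.30 log units; within the scatter), so methyl, tert-butyl and phenyl all stand within the scatter of one another at this place. Among the compounds shown here, the one step beyond the scatter keeps phenyl in place, a 6.0-fold higher number from compound 1 to compound 4 (0.78 log units; beyond the scatter). The lower number of compound 1 therefore cannot be credited to phenyl alone, because of this: the fact that compounds 1 and 4 differ only in the configuration as drawn.

The compounds shown leave open whether the configuration drawn in compound 1 would give a similar gap with methyl or tert-butyl in place of phenyl. They also leave open whether an amine or a carboxylic acid on this carbonyl carbon would move the number at all.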